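Methylating the Ring Amide Nitrogen of Compound 3

This account rests on a few compounds, and the source may have more. Where it says the series, first, only, none or still open, it means among the compounds named here.

Measured compounds:
Compound 1 `CN1C[C@@H](c2ccc(Cl)cc2)[C@@]2(Cc3ccccc3C2=O)[C@@]12C(=O)Nc1ccccc12`: 63.4%
Compound 2 `CN1C(=O)[C@@]2(c3ccccc31)N(C)C[C@@H](c1ccc(Cl)cc1)[C@@]21Cc2ccccc2C1=O`: 86.6%
Compound 3 `COc1ccc([C@@H]2CN(C)[C@]3(C(=O)Nc4ccccc43)[C@]23Cc2ccccc2C3=O)cc1`: 33.3%

All three were tested in a functional assay on RPMI18226 cells (Homo sapiens) for antiproliferative activity, read by sulforhodamine B assay, with a stated time of 48 h, tested at 10 uM; on this read-out higher numbers stand for more inhibition at the one concentration tested (going by the name of the read-out) and lower numbers for less inhibition. Compound 3 stands lowest of the three numbers; its nearest neighbour is compound 1, separated by a number 30.1 percentage points lower from compound 1 to compound 3 (beyond the scatter), and compound 2 lies furthest above it.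

Compound 4 `COc1ccc([C@@H]2CN(C)[C@]3(C(=O)N(C)c4ccccc43)[C@]23Cc2ccccc2C3=O)cc1` has not yet been measured. It differs from compound 3 in one place: methyl in place of hydrogen on an amide-type nitrogen in a ring. The same change has been seen once before within this set, where it gave a number 23.2 percentage points higher from compound 1 to compound 2 (beyond the scatter), a rise beyond the scatter. If that step carries over to the methoxy-bearing core, a gain of similar size is expected, a number 21.7 percentage points higher from compound 3 to compound 4 (beyond the scatter). On that basis compound 4 is estimated at 55%, with a likely range from 35% to 75%.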

Compound 4, a percentage reported as inhibition, at one concentration (the size of the read-out at that concentration, not a potency): 82.3%
Beside the measured number, compound 4's estimate is 27.3 percentage points below it; measured number above the stated range.
By their numbers in this assay, from the lowest: compound 3; then compound 1; then compounds 4 and 2 (each within the scatter of the next).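

Methyl in place of hydrogen on this amide-type nitrogen gives a number 49 percentage points higher from compound 3 to compound 4 (beyond the scatter) on the methoxy-bearing core, so the size of the gain depends on what else the core carries: the same change on two cores in this assay, a number 23.2 percentage points higher (beyond the scatter) from compound 1 to compound 2 and a number 49 percentage points higher (beyond the scatter) from compound 3 to compound 4, 25.8 percentage points apart, beyond the scatter of two such steps.

With that methyl in place, methoxy in place of chloro gives a number 4.3 percentage points lower from compound 2 to compound 4 (within the scatter) and the clear drop seen with the amide hydrogen does not appear: the same change on two cores in this assay, a number 30.1 percentage points lower (beyond the scatter) from compound 1 to compound 3 and a number 4.3 percentage points lower (within the scatter) from compound 2 to compound 4, 25.8 percentage points apart, beyond the scatter of two such steps.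

Going by these compounds, whether a longer chain such as ethyl on this nitrogen would behave like methyl stays open, as does how an amine on that aromatic carbon would compare with chloro or methoxy. All four numbers come from one concentration, so they do not give potency.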